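The source may hold more compounds than are shown below. What is called first, only, known or untested is meant among the compounds shown, and "the series" means these compounds.

The measured compounds:
- compound 1, `CCCCCCCCCCc1ccc(-c2noc([C@@H]3CCC[C@@H](N)C3)n2)cc1`: in an assay on HeLa cells for inhibition of sphingosine-1-phosphate transporter SPNS2 (Mus musculus), read by LC-MS, tested at 2 uM (a higher number here means more inhibition at the concentration tested (going by the name of the read-out), a lower number less inhibition), compound 1 gives 13%
- compound 2, `CCCCCCCCCCc1ccc(-c2noc(CC[C@@H](N)C(=O)O)n2)cc1`: in this assay compound 2 gives 5%

Of these two numbers, compound 2 carries the smaller, but the step of a number 8 percentage points lower from compound 1 to compound 2 (within the scatter) lies within the scatter, so the two numbers are to be taken as level. Compound 3, `CCCCCCCCCCc1ccc(-c2noc(C(Cl)CCN)n2)cc1`, differs from compound 2 at one place: a group of 5 heavy atoms (3 carbon, 1 nitrogen, 1 chlorine; no ring) in place of a group of 7 heavy atoms (4 carbon, 1 nitrogen, 2 oxygen; no ring), on an aromatic carbon. Going by the values given here, the only measured step, from compound 1 to compound 2, also swapped the group at this place and stayed within the scatter, so little guidance exists. A change no larger than the scatter is expected, a number 5 percentage points higher from compound 2 to compound 3 (within the scatter). Compound 3 is estimated at 10%, ranging from 0% to 30%.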

Compound 3, a percentage reported as inhibition, at one concentration (the size of the read-out at that concentration, not a potency): 5%
Compound 3: middle estimate off by 5 percentage points, on the high side, within the range that was stated.
By their numbers in this assay, from the lowest: compounds 2, 3 and 1 (each within the scatter of the next).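

With the chlorine-bearing open chain at this aromatic carbon, replacing 3-amino-3-carboxypropyl gives no change at the digits printed from compound 2 to compound 3 (within the scatter), and replacing 3-aminocyclohexyl gives a number 8 percentage points lower from compound 1 to compound 3 (within the scatter). A third, different group at this position therefore reads level with the other two in this assay, so neither the ring nor the carboxylic acid separates these compounds here. No other measurement helps to explain this level reading. As far as these compounds go, it remains open whether any group at this position can rise clear of the scatter. A longer chain ending in an amine, or a carboxylic acid without the amine, would test this.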